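A few compounds are considered here, and "the series" means these few. Any claim that something is new, unique, unknown or untested is made for them only; others in the source may bear on it.

Two measured members of the series frame the change. Compound 1 `CCN(CC)c1ccc2cc(C(=O)NCCO)c(=O)oc2c1` carries a hydroxyethyl amide on the shared core. In a functional assay on HCT-116 cells (Homo sapiens) for cytotoxicity, read by MTT assay, with a stated time of 72 h (a higher number here means a weaker inhibitor, a lower number a stronger inhibitor), compound 1 returns only a limit, > 100000 nM, and no number. Compound 2 `CCN(CC)c1ccc2cc(C(=O)N/N=C(/C)c3cccs3)c(=O)oc2c1` replaces that amide substituent with a hydrazone bearing thiophen-2-yl. In this assay compound 2 likewise returns only a limit, > 100000 nM. The step that the two limits leave unreadable from compound 1 to compound 2 therefore cannot be sized, since (the limit of > 100000 nM in this assay, at which 2 of the 2 values shown sit); compound 2 stands at that limit with no number of its own.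

Compound 3 `CCN(CC)c1ccc2cc(C(=O)N/N=C(/C)c3cccnc3)c(=O)oc2c1` is the next member. It differs from compound 2 by pyridin-3-yl in place of thiophen-2-yl on a carbon with a double bond to nitrogen. Within the data shown here, no measured step bears on this change: the only step in hand, from the hydroxyethyl amide to the thiophene hydrazone, is itself unreadable, so nothing shows that exchanging the aromatic ring on the hydrazone carbon moves this read-out.

Because compound 2 sits at > 100000 nM, compound 3 is expected to stay near that limit as well. The expected step of a number no higher from compound 2 to compound 3 (the limit leaves the size open) is none beyond the scatter. The estimate for compound 3 in this assay is 100000 nM, with a range from 30000 nM to 300000 nM.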

Compound 3, half-maximal inhibitory concentration: > 100000 nM
Compound 3: a limit, no number; the forecaster's own chance of this, stated with the estimate: 75%; the middle value lies on the limit itself.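

In this assay compound 3 gives > 100000 nM, a limit and not a number. No step among compound 1, compound 2 and compound 3 can be read: the limit of > 100000 nM in this assay, at which 3 of the 3 values shown sit.

The compounds shown leave open whether any substituent on the amide nitrogen of the shared core, hydrazone or otherwise, can move this read-out to a measurable number.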